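Two Aryl Sulfonamides and an Untested Long-Chain Analogue

The compounds below may be only part of what the source reports. "The series", "measured", "known", "first", "only" and "open" are said of these compounds alone.

Measured so far:
compound 1 `CC(=O)Nc1nc(-c2cccc(NS(=O)(=O)c3cccc(Br)c3)c2)cs1` — 67.4%
compound 2 `CC(=O)Nc1nc(-c2cccc(NS(=O)(=O)c3ccc(C#CCO)cc3)c2)cs1` — 99.3%

In a functional assay on A-375 cells (Homo sapiens) for antiproliferative activity, read by trypan blue exclusion, with a stated time of 48 h, tested at 5 uM (a higher number here means a weaker effect of the compound at the concentration tested, a lower number a stronger effect), compound 2 gives 99.3%, the highest of the two numbers, and compound 1 gives 67.4%, a number lower by more than the usual scatter. Compound 3 `CCCCCCCCC#Cc1ccc(S(=O)(=O)Nc2cccc(-c3csc(NC(C)=O)n3)c2)cc1` differs from compound 2 in one place: heptyl in place of hydroxy on a saturated chain carbon bound to a triple-bonded carbon. For the measured compounds named here, no measured step matches this change, so the direction rests on little. A downward step is expected, likely beyond the scatter, though a result within the scatter of compound 2 cannot be ruled out. For compound 3 the estimated step is a number 21.3 percentage points lower from compound 2 to compound 3 (beyond the scatter), giving an expected value of 78% with a range from 45% to 100%.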

Compound 3, a percentage reported as activity, at one concentration (the size of the read-out at that concentration, not a potency): 8.9%
Compound 3: middle estimate off by 69.1 percentage points, on the high side, and the stated range ends above it.
By their numbers in this assay, from the lowest: compound 3; then compound 1; then compound 2.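

In this assay, heptyl in place of hydroxy on a saturated chain carbon bound to a triple-bonded carbon gives a number 90.4 percentage points lower from compound 2 to compound 3 (beyond the scatter), showing that the read-out is highly sensitive to this change at this position. This single pair cannot separate the gain of the heptyl chain from the loss of the hydroxy. No measured evidence accounts for the step. Going by these compounds, it remains open whether a propyl group or a longer chain would give a similar read-out, and how an amine or a carboxylic acid at this position would compare.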